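The source may report more compounds than this note shows. Statements on the series, on what has been measured and on what is new or still open speak of the compounds shown alone.

Measured so far in a functional assay on MCF7 cells (Homo sapiens) for cytotoxicity, read by MTT assay, with a stated time of 24 h, tested at 80 ug/mL; on this read-out higher numbers stand for a stronger effect at the one concentration tested and lower numbers for a weaker effect:
compound 1 `Cn1c(-c2ccc(NC(=O)CSc3nc4ccccc4s3)cc2)nc(-c2ccccc2)c1-c1ccccc1` gives 76.6%;
compound 2 `Cn1ccnc1SCC(=O)Nc1ccc(-c2nc(-c3ccccc3)c(-c3ccccc3)n2C)cc1` gives 64%.

Compound 2 stands lowest of these two numbers. Compound 3 `CN(C)/C=C/N1CCN(CC(=O)Nc2ccc(-c3nc(-c4ccccc4)c(-c4ccccc4)n3C)cc2)CC1` differs from it in one place: 4-(2-(dimethylamino)ethenyl)piperazin-1-yl in place of (1-methyl-1H-imidazol-2-yl)sulfanyl on a saturated chain carbon bound to a carbonyl carbon. Among the measured compounds shown here, the only measured step, a number 12.6 percentage points lower from compound 1 to compound 2 (beyond the scatter), swapped one ring for another on a sulfur, so it bears on the present change only loosely, showing that exchanging the group at this end can move the read-out modestly. Here the whole (1-methyl-1H-imidazol-2-yl)sulfanyl group is replaced, not just its ring, so a modest downward step, with wide uncertainty, is expected: a number 9 percentage points lower from compound 2 to compound 3 (within the scatter). Compound 3 is estimated at 55%, within 30% to 75%.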

Compound 3, a percentage reported as activity, at one concentration (the size of the read-out at that concentration, not a potency): 34.7%
Beside the measured number, compound 3's estimate is 20.3 percentage points above it, and the stated range covers the measured number.
By their numbers in this assay, from the lowest: compound 3; then compound 2; then compound 1.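

In this assay, placing 4-(2-(dimethylamino)ethenyl)piperazin-1-yl on the saturated chain carbon bound to a carbonyl carbon lowers the read-out against both sulfur-linked groups (a number 29.3 percentage points lower from compound 2 to compound 3 (beyond the scatter); a number 41.9 percentage points lower from compound 1 to compound 3 (beyond the scatter)). This exchange of the whole group moves the number further than changing only the ring on sulfur did. Nothing shown explains the drop. Still open, on these data alone, is whether the loss of the sulfur, the piperazine ring or the 2-(dimethylamino)ethenyl arm drives the step. An unsubstituted piperazine or a morpholine on the same carbon would help separate these.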